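Trading an Aryl Group for a Butyl Chain

A few compounds are considered here, and "the series" means these few. Any claim that something is new, unique, unknown or untested is made for them only; others in the source may bear on it.

In a functional assay on MOLT-4 cells (Homo sapiens) for antiproliferative activity, read by MTT assay, with a stated time of 3 days (on this read-out higher numbers stand for weaker inhibition and lower numbers for stronger inhibition), compound 1 (`O=C1c2ccccc2C(=O)N1C/C=C\Cn1cc(C#Cc2ccc(Br)cc2)c(=O)[nH]c1=O`) gives 89000 nM, the highest number and so the weakest inhibition of the three measured compounds. Compound 2 (`CCCCCCC#Cc1cn(C/C=C/CN2C(=O)c3ccccc3C2=O)c(=O)[nH]c1=O`) gives 35000 nM, and compound 3 (`CCCCCc1ccc(C#Cc2cn(C/C=C/CN3C(=O)c4ccccc4C3=O)c(=O)[nH]c2=O)cc1`) gives 17000 nM. Compound 4 (`CCCCC#Cc1cn(C/C=C\CN2C(=O)c3ccccc3C2=O)c(=O)[nH]c1=O`) has not yet been measured. It carries butyl in place of 4-bromophenyl on a triple-bonded carbon.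

Among the compounds with values here, only one measured step resembles this change: a 2.1-fold lower number from compound 2 to compound 3 (0.31 log units; beyond the scatter), where 4-pentylphenyl replaces hexyl. Read backwards, this modest step suggests that a chain in place of the ring could raise the number slightly. However, compound 2 and compound 3 have the other double-bond geometry in their linker, so the comparison is only loose. Also, compound 2, which has a chain there, gives 35000 nM, a lower number than compound 1 gives. Little net change is therefore expected, an estimated 1.1-fold lower number from compound 1 to compound 4 (0.05 log units; within the scatter). For compound 4 the estimated value is 80000 nM, with an expected range of 35000 nM to 170000 nM.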

Compound 4, half-maximal inhibitory concentration: 41000 nM
Estimate against measurement, compound 4: 2.0-fold (0.29 log units) above; the measured number falls inside the stated range.
By their numbers in this assay, from the lowest: compound 3; then compounds 2 and 4 (each within the scatter of the next); then compound 1.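

In this assay, an aromatic ring on this triple-bonded carbon proves unnecessary for holding the number down: butyl in place of 4-bromophenyl gives a 2.2-fold lower number from compound 1 to compound 4 (0.34 log units; beyond the scatter), a modest step. This runs opposite to a 2.1-fold lower number from compound 2 to compound 3 (0.31 log units; beyond the scatter), where the ring-bearing 4-pentylphenyl replaced the open chain hexyl, so across these two pairs neither a ring nor a chain gives the lower number every time. No measured evidence is available to account for the step.

Going by these compounds, the two pairs differ in their double-bond geometry and in their groups, so it stays open whether the direction depends on the linker or on the particular ring and chain. Also open, on these data alone, is how a chain ending in an amine, or a longer chain such as octyl, would behave on this geometry.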